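Methoxy for benzyloxy on the oxime of compound 3

The source may hold more compounds than are shown below. What is called first, only, known or untested is meant among the compounds shown, and "the series" means these compounds.

In a functional assay on cells for agonist activity at P2Y purinoceptor 6 (Homo sapiens), read by FLIPR and calcium flux (a higher number here means that more compound is needed for the effect, a lower number that less compound is needed), compound 1 `CO/N=c1/ccn([C@]23C[C@H]2[C@H](COP(=O)(O)OP(=O)(O)OP(=O)(O)OC[C@@]24C[C@@H]2[C@@H](n2ccc(=O)[nH]c2=O)[C@H](O)[C@@H]4O)[C@@H](O)[C@H]3O)c(=O)[nH]1` gives 705 nM, compound 2 `CO/N=c1/ccn([C@]23C[C@H]2[C@H](COP(=O)(O)OP(=O)(O)OP(=O)(O)OC[C@@H]2[C@@H](O)[C@@H](O)[C@@]4(n5ccc(=O)[nH]c5=O)C[C@@H]24)[C@@H](O)[C@H]3O)c(=O)[nH]1` gives 6900 nM and compound 3 `O=c1[nH]/c(=N\OCc2ccccc2)ccn1[C@]12C[C@H]1[C@H](COP(=O)(O)OP(=O)(O)O)[C@@H](O)[C@H]2O` gives 793 nM. Compound 3 thus stands second highest of the three numbers; its value and that of compound 1 lie within the scatter, while compound 2 sits well beyond it at the high end. Compound 4 `CO/N=c1/ccn([C@]23C[C@H]2[C@H](COP(=O)(O)OP(=O)(O)O)[C@@H](O)[C@H]3O)c(=O)[nH]1` differs from compound 3 only by hydrogen in place of phenyl on a saturated chain carbon bound to an oxygen, that is, benzyloxy to methoxy on the oxime. Within the data shown here, no step of that kind between measured compounds is available, and compound 1 carries the same methoxy oxime with a value close to compound 3. The step from compound 3 to compound 4 in this assay is therefore expected to stay within the scatter, a 1.4-fold lower number from compound 3 to compound 4 (0.16 log units; within the scatter). Compound 4 is estimated at 550 nM, with a range of 150 nM to 2000 nM.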

Compound 4, half-maximal effective concentration: 493 nM
Compound 4: middle estimate off by 1.1-fold (0.05 log units), on the high side, within the range that was stated.
By their numbers in this assay, from the lowest: compounds 4, 1 and 3 (each within the scatter of the next); then compound 2.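

In this assay, the oxime substituent now has its first comparison in one place: the step of a 1.6-fold lower number from compound 3 to compound 4 (0.21 log units; within the scatter) stays within the scatter for hydrogen in place of phenyl on a saturated chain carbon bound to an oxygen. Benzyloxy and methoxy on the oxime are therefore not told apart in this pair, and the phenyl ring is not required for a value of this order. No measured evidence bears on this result.

Open, from the compounds shown here alone, is whether an oxime ether carrying a longer chain, an amine or a carboxylic acid keeps such a value. Also open, going by these compounds, is whether the same change reads alike on the core of compound 1.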